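The source may hold more compounds than are shown below. What is called first, only, known or untested is meant among the compounds shown, and "the series" means these compounds.

Of the compounds shown here, three have been measured in a functional assay on HOP-92 cells (Homo sapiens) for cytotoxicity, read by sulforhodamine B assay, with a stated time of 48 h; on this read-out lower numbers stand for stronger inhibition of growth and higher numbers for weaker inhibition of growth. Compound 1 `ClCc1ccccc1Cn1cnc2c(Cl)nc(Cl)nc21` gave 970 nM in this assay, while compound 2 `ClCc1ccccc1Cn1cnc2c(Cl)ncnc21` gave 4260 nM. The two differ in one place, (chloro in place of hydrogen on an aromatic carbon), and that change produced a step of a 4.4-fold lower number from compound 2 to compound 1 (0.64 log units; beyond the scatter). Compound 3 `ClCc1cccc(Cn2cnc3c(Cl)ncnc32)c1` gave 6160 nM in this assay; it has the same atoms as compound 2 joined differently, and the difference between the two cores is not broken down here. Its number and that of compound 2 lie within the usual scatter of each other and cannot be told apart. Compound 4 `ClCc1cccc(Cn2cnc3c(Cl)nc(Cl)nc32)c1` has not yet been measured. It stands to compound 3 as compound 1 stands to compound 2, carrying (chloro in place of hydrogen on an aromatic carbon), the same change at the same place. If the step it brings resembles a 4.4-fold lower number from compound 2 to compound 1 (0.64 log units; beyond the scatter), the number for compound 4 is expected to come out lower than that of compound 3, though this rests on a single earlier pair. Compound 4 is therefore estimated at 1500 nM, with a range from 700 nM to 3500 nM, which means an expected step of a 4.1-fold lower number from compound 3 to compound 4 (0.61 log units; beyond the scatter).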

Compound 4, concentration for total growth inhibition: 3630 nM
Compound 4: middle estimate off by 2.4-fold (0.38 log units), on the low side, outside the stated range (above it).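

In this assay, chloro in place of hydrogen on an aromatic carbon gives a 1.7-fold lower number from compound 3 to compound 4 (0.23 log units; within the scatter) on the core of compound 3, so compound 3 and compound 4 cannot be told apart on this change alone. Set beside the step on the core of compound 2, this result cannot be separated from the earlier one: the same change on two cores in this assay, a 4.4-fold lower number (0.64 log units; beyond the scatter) from compound 2 to compound 1 and a 1.7-fold lower number (0.23 log units; within the scatter) from compound 3 to compound 4, 2.6-fold (0.41 log units) apart, within the scatter of two such steps. The two cores therefore give no firm sign that the change behaves differently from one to the other, but they do not show that it carries over in full either, since the step passes the scatter on one core and not on the other, and two pairs are too few to settle the matter.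

The compounds shown leave open what an amine or a methoxy group would do in the same place, on an aromatic carbon between two ring nitrogen atoms. They also leave open whether the chloro step would hold up on any other cell line.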